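The source may hold more compounds than are shown below. What is called first, only, known or untested is meant among the compounds shown, and "the series" means these compounds.

Measured in a functional assay on HT-29 cells (Homo sapiens) for inhibition, read by sulforhodamine B assay, with a stated time of 72 h; a higher number here means a weaker inhibitor, a lower number a stronger inhibitor:
compound 1 `CCSc1ccc(C2C(Oc3ccccc3)C(=O)N2c2cc(OC)c(OC)c(OC)c2)cc1`: 632 nM
compound 2 `COc1ccc(C2C(C3CC3)C(=O)N2c2cc(OC)c(OC)c(OC)c2)cc1`: 107 nM

Compound 2 holds the lower of the two numbers, a gap beyond the scatter. Compound 3 `CCSc1ccc(C2C(C3CC3)C(=O)N2c2cc(OC)c(OC)c(OC)c2)cc1` has ethylsulfanyl in place of methoxy on an aromatic carbon of compound 2, para to a large group (ethylsulfanyl in place of methoxy on an aromatic carbon). For the measured compounds named here, no measured pair isolates this change. Compound 1 also carries ethylsulfanyl and gives 632 nM in this assay, but it differs from compound 2 elsewhere as well, so only a small rise in the number is expected, about the size of the scatter. The expected step is a 1.9-fold higher number from compound 2 to compound 3 (0.27 log units; within the scatter) in this direction. The estimate for compound 3 is 200 nM, with 60 nM to 650 nM as its expected range.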

Compound 3, half-maximal inhibitory concentration: 1560 nM
Compound 3: the middle estimate sits 7.8-fold (0.89 log units) below what was measured; measured number outside the range, above it.
By their numbers in this assay, from the lowest: compound 2; then compound 1; then compound 3.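

In this assay, ethylsulfanyl in place of methoxy on the aromatic carbon gives a 15-fold higher number from compound 2 to compound 3 (1.16 log units; beyond the scatter), so with cyclopropyl kept, this position responds strongly to the change. With ethylsulfanyl kept, cyclopropyl in place of phenoxy on a saturated ring carbon gives a 2.5-fold higher number from compound 1 to compound 3 (0.39 log units; beyond the scatter), a modest step beside the large one. No measurement shown here accounts for the size of either step. Going by these compounds, whether the methoxy to ethylsulfanyl step would be as large with phenoxy on the saturated ring carbon remains open. So does the response of this aromatic position to methylsulfanyl or a hydroxyl group.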